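This account rests on a few compounds, and the source may have more. Where it says the series, first, only, none or still open, it means among the compounds named here.

Measured so far:
compound 1 `CC(Sc1nc2c(cnn2C)c(=O)n1-c1ccccc1)c1cccc(F)c1`, 110 nM
compound 2 `CC(Sc1nc2c(cnn2C)c(=O)n1-c1ccccc1)c1cccnc1`, 89 nM

In an assay on isolated protein for inhibition of retinal dehydrogenase 2 (Homo sapiens) (a higher number here means a weaker inhibitor, a lower number a stronger inhibitor), compound 1 gives 110 nM and compound 2 gives 89 nM. Compound 2 sits at the low end of these two numbers, yet the step of a 1.2-fold lower number from compound 1 to compound 2 (0.09 log units; within the scatter) is within the scatter, so compound 1 and compound 2 are not separated. Compound 3 `COc1ccccc1C(C)Sc1nc2c(cnn2C)c(=O)n1-c1ccccc1` differs from compound 2 by 2-methoxyphenyl in place of pyridin-3-yl on a saturated chain carbon bound to a saturated chain carbon and a sulfur. Within the data shown here, the only step that bears on this place is a 1.2-fold lower number from compound 1 to compound 2 (0.09 log units; within the scatter), an exchange of the aryl group on the same carbon that barely moved the number. With one such swap on record, the expected step of a 1.1-fold higher number from compound 2 to compound 3 (0.05 log units; within the scatter) is no larger than the scatter. Compound 3 is estimated at 100 nM, between 40 nM and 250 nM.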

Compound 3, half-maximal inhibitory concentration: 136 nM
Estimate against measurement, compound 3: 1.4-fold (0.13 log units) below; the measured number falls inside the stated range.
By their numbers in this assay, from the lowest: compounds 2, 1 and 3 (each within the scatter of the next).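

On the saturated chain carbon bound to a saturated chain carbon and a sulfur, 2-methoxyphenyl does not separate from the other two aryl groups in this assay: there is a 1.5-fold higher number from compound 2 to compound 3 (0.18 log units; within the scatter), and a 1.2-fold higher number from compound 1 to compound 3 (0.09 log units; within the scatter). All three groups now fall within the scatter of one another, so this position has yet to show a real difference among aryl groups. No available evidence bears on this result.

Still open, going by these compounds, is whether an amine, a carboxylic acid or a longer chain on this carbon would move the number beyond the scatter.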